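Methoxy to Hydroxy on a Pyrazole Amide Series

This account rests on a few compounds, and the source may have more. Where it says the series, first, only, none or still open, it means among the compounds named here.

Measured compounds:
- compound 1 `COc1cc(-c2nn(-c3ccc(NC(=O)c4ccc(Cl)c(C(F)(F)F)c4)cc3)cc2-c2ccncc2)ccc1Cl`: 9800 nM
- compound 2 `COc1cc(-c2nn(-c3ccc(NC(=O)c4cc(C(F)(F)F)cc(C(F)(F)F)c4)cc3)cc2-c2ccncc2)ccc1Cl`: > 20000 nM

In a functional assay on A375P cells (Homo sapiens) for antiproliferative activity, read by MTT assay, with a stated time of 48 h (on this read-out higher numbers stand for weaker inhibition and lower numbers for stronger inhibition), compound 1 gives 9800 nM. Compound 2 reaches only the limit of this assay, > 20000 nM, so for compound 2 no number is known, only that it sits at the limit (the limit of > 20000 nM in this assay, at which 1 of the 2 values shown sits). Compound 3 `O=C(Nc1ccc(-n2cc(-c3ccncc3)c(-c3ccc(Cl)c(O)c3)n2)cc1)c1cc(C(F)(F)F)cc(C(F)(F)F)c1` has not been measured. It differs from compound 2 in one place: hydrogen in place of methyl on an oxygen on an aromatic ring. For the measured compounds named here, no measured pair shows what this change does in this assay, so there is no step to lean on. The expectation is that the step from compound 2 to compound 3, a step that the limit leaves unreadable from compound 2 to compound 3, is small and may not exceed the usual scatter of the measurement. Compound 3 is therefore estimated at 25000 nM, within a range from 8000 nM to 80000 nM, with a real chance that the assay again reports only a limit.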

Compound 3, half-maximal inhibitory concentration: > 20000 nM
Compound 3 gave a limit, no number (the forecaster's own chance of this, stated with the estimate: 60%); the middle value does not contradict the limit.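

Compound 2 and compound 3 both give only a limit rather than a number, so the step between them cannot be read: the limit of > 20000 nM in this assay, at which 2 of the 3 values shown sit.

From the compounds shown here alone, whether methoxy to hydroxy changes activity in either direction stays open, including on a compound with a measurable value, such as compound 1.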